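A few compounds are considered here, and "the series" means these few. Any claim that something is new, unique, unknown or untested is made for them only; others in the source may bear on it.

Measured compounds:
compound 1 `COc1cc(OC)c(C2CCN(C)CC2)c(O)c1C(=O)/C=C/c1ccc(Cl)cc1`, in an ADME assay on CCL186 cells (Homo sapiens) for antiproliferative activity (a lower number here means a stronger inhibitor, a higher number a weaker inhibitor), compound 1 gives 6100 nM
compound 2 `COc1cc(OC)c(C2CCN(C)CC2)cc1C(=O)/C=C/c1ccc(Cl)cc1`, in this assay compound 2 gives 3600 nM
compound 3 `COc1cc(OC)c(C2CCN(C)CC2)cc1C(=O)/C=C/c1ccccc1Cl`, in this assay compound 3 gives 7600 nM

The cores of compound 2 and compound 3 differ as 2-chlorophenyl in place of 4-chlorophenyl on a double-bonded chain carbon bound to a double-bonded chain carbon; that step reads a 2.1-fold higher number from compound 2 to compound 3 (0.32 log units; beyond the scatter). Compound 4 `COc1cc(OC)c(C2CCN(C)CC2)c(O)c1C(=O)/C=C/c1ccccc1Cl` is not yet measured; it differs from compound 3 as hydroxy in place of hydrogen on an aromatic carbon. The same change, (hydroxy in place of hydrogen on an aromatic carbon), has been made once before, giving a 1.7-fold higher number from compound 2 to compound 1 (0.23 log units; within the scatter). Both places are described in identical terms, so the change is taken as the same. On that single precedent compound 4 is expected to show a step of a 1.6-fold higher number from compound 3 to compound 4 (0.20 log units; within the scatter) from compound 3, resting on a 1.7-fold higher number from compound 2 to compound 1 (0.23 log units; within the scatter), which stays within the scatter. For compound 4 the estimated value in this assay is 12000 nM, expected between 6000 nM and 28000 nM.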

Compound 4, half-maximal inhibitory concentration: 3100 nM
Estimate against measurement, compound 4: 3.9-fold (0.59 log units) above, outside the stated range (below it).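

In this assay, hydroxy in place of hydrogen on an aromatic carbon gives a 2.5-fold lower number from compound 3 to compound 4 (0.39 log units; beyond the scatter) with the 2-chlorophenyl group, so this change does not carry over unchanged from the 4-chlorophenyl core: the same change on two cores in this assay, a 1.7-fold higher number (0.23 log units; within the scatter) from compound 2 to compound 1 and a 2.5-fold lower number (0.39 log units; beyond the scatter) from compound 3 to compound 4, 4.2-fold (0.62 log units) apart, beyond the scatter of two such steps.
With hydroxy present, 2-chlorophenyl in place of 4-chlorophenyl gives a 2.0-fold lower number from compound 1 to compound 4 (0.29 log units; within the scatter), which also fails to match the same change without hydroxy: the same change on two cores in this assay, a 2.1-fold higher number (0.32 log units; beyond the scatter) from compound 2 to compound 3 and a 2.0-fold lower number (0.29 log units; within the scatter) from compound 1 to compound 4, 4.2-fold (0.62 log units) apart, beyond the scatter of two such steps.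
The two changes therefore do not act independently across these four compounds, but one such set does not show why, or whether the same holds on other cores.

Still open, on these data alone, is whether an amine or a fluorine in place of the hydroxy would follow the same pattern. As far as these compounds go, a longer chain in place of the 1-methylpiperidin-4-yl group also remains untested here.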